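The source may hold more compounds than are shown below. What is called first, only, known or untested is meant among the compounds shown, and "the series" means these compounds.

In a physicochemical assay for solubility, read by HPLC, in phosphate buffer, measured as kinetic solubility, at pH 7.4 (on this read-out higher numbers stand for higher solubility and lower numbers for lower solubility), compound 1 `NS(=O)(=O)c1ccc(-c2cc(C(=O)CC3CCC3)nn2-c2ccc(Cl)cc2)cc1` gives 4300 nM and compound 2 `NS(=O)(=O)c1ccc(-c2cc(C(=O)N3CC4CC4C3)nn2-c2ccc(Cl)cc2)cc1` gives 36600 nM, the higher of the two numbers. Compound 3 `NS(=O)(=O)c1ccc(-c2cc(C(=O)N3CCCC3)nn2-c2ccc(Cl)cc2)cc1` has not been measured yet. It differs from compound 2 as follows: a group of 5 heavy atoms (4 carbon, 1 nitrogen; one five-membered non-aromatic ring with 1 hetero atom) in place of a group of 6 heavy atoms (5 carbon, 1 nitrogen; one three-membered non-aromatic ring of carbon only, one five-membered non-aromatic ring with 1 hetero atom), on a carbonyl carbon. Within the data shown here, the one measured step at this carbonyl carbon is an 8.5-fold higher number from compound 1 to compound 2 (0.93 log units; beyond the scatter). That step exchanged a different pair of groups and gives no direct measure for this change. The expected step is a 1.1-fold higher number from compound 2 to compound 3 (0.04 log units; within the scatter), with no change beyond the scatter expected in either direction. Compound 3 is estimated at 40000 nM, within a range of 15000 nM to 100000 nM.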

Compound 3, solubility: 57900 nM
Estimate against measurement, compound 3: 1.4-fold (0.16 log units) below; measured number inside the range.
By their numbers in this assay, from the lowest: compound 1; then compounds 2 and 3 (each within the scatter of the next).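

In this assay the three-membered ring carried by compound 2 leaves no readable mark on this carbonyl carbon: the change to pyrrolidin-1-yl gives a 1.6-fold higher number from compound 2 to compound 3 (0.20 log units; within the scatter). Pyrrolidin-1-yl in place of cyclobutylmethyl gives a 13-fold higher number from compound 1 to compound 3 (1.13 log units; beyond the scatter), so a second group joined through its ring nitrogen also stands clear of compound 1. No measurement here explains that gap.

Still open, from the compounds shown here alone, is whether morpholin-4-yl, or an open-chain group such as diethylamino, on this carbonyl carbon would give a number like those of compound 2 and compound 3.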